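Ethyl to Isopropyl on the Shared Core

A few compounds are considered here, and "the series" means these few. Any claim that something is new, unique, unknown or untested is made for them only; others in the source may bear on it.

Compound 1 `CCCCNc1nc(C)nc2c1cnn2-c1ccccc1` reaches only a limit in a functional assay on G-361 cells (Homo sapiens) for cytotoxicity, read by sulforhodamine B assay (on this read-out lower numbers stand for stronger inhibition of growth and higher numbers for weaker inhibition of growth), giving > 100000 nM rather than a number. Compound 2 `CCCCNc1nc(CC)nc2c1cnn2-c1ccccc1` gives 32000 nM in this assay, the only number shown, with the other value being (the limit of > 100000 nM in this assay, at which 1 of the 2 values shown sits). Among the compounds with values here, the step of an at least 3.1-fold lower number from compound 1 to compound 2 (0.49 log units; beyond the scatter) is the one measured change here. Compound 3 `CCCCNc1nc(C(C)C)nc2c1cnn2-c1ccccc1` differs from compound 2 by methyl in place of hydrogen on a saturated chain carbon bound to an aromatic carbon and a saturated chain carbon, the same kind of change carried one bond further out. Because the step of an at least 3.1-fold lower number from compound 1 to compound 2 (0.49 log units; beyond the scatter) went downward, a smaller step in that direction is expected, a 2.0-fold lower number from compound 2 to compound 3 (0.30 log units; within the scatter). Compound 3 is therefore estimated at 16000 nM, between 5000 nM and 60000 nM.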

Compound 3, concentration for total growth inhibition: > 100000 nM
Compound 3: only a limit was reported (the forecaster's own chance of this, stated with the estimate: 10%); middle value at least 6.2-fold (0.79 log units) from the limit.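

Ethyl to isopropyl gives an at least 3.1-fold higher number from compound 2 to compound 3 (0.49 log units; beyond the scatter) in this assay, so the downward direction seen on going from methyl to ethyl does not continue on this carbon. Among these groups, only the ethyl of compound 2 gives a number rather than a limit. The step between compound 1 and compound 3 cannot be read, as both values are limits: the limit of > 100000 nM in this assay, at which 2 of the 3 values shown sit.

Going by these compounds, whether a straight propyl chain or a cyclopropyl ring in this place would give a number like that of compound 2 remains open. So does the effect of an amine or a methoxy group there.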